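Changing the Sulfonyl Group's Ring on Compound 3

The source may hold more compounds than are shown below. What is called first, only, known or untested is meant among the compounds shown, and "the series" means these compounds.

In a functional assay on HepG2 cells (Homo sapiens) for antiproliferative activity, read by MTT assay, with a stated time of 24 h (on this read-out higher numbers stand for weaker inhibition and lower numbers for stronger inhibition), compound 1 (`Cc1ccc(-c2nn(-c3ccccc3)cc2-c2nc3ccccc3[nH]2)cc1`) gives 6260 nM and compound 2 (`FC(F)(F)c1ccc(-c2nn(-c3ccccc3)cc2-c2nc3ccccc3[nH]2)cc1`) gives 6030 nM. Compound 3 (`Cc1ccc(-c2nn(-c3ccccc3)cc2-c2nc3ccccc3n2S(=O)(=O)c2cc(C)ccc2C)cc1`) gives 460 nM, the lowest of the three numbers. Compound 4 (`Cc1ccc(-c2nn(-c3ccccc3)cc2-c2nc3ccccc3n2S(=O)(=O)c2ccc(Br)cc2)cc1`) has 4-bromophenyl in place of 2,5-dimethylphenyl on a sulfonyl sulfur. Among the compounds with values here, no measured pair makes this exact change. Adding (2,5-dimethylphenyl)sulfonyl in place of hydrogen on an aromatic nitrogen gave a large step, a 14-fold lower number from compound 1 to compound 3 (1.13 log units; beyond the scatter). Compound 4 keeps a sulfonyl group at that nitrogen. Trifluoromethyl in place of methyl on an aromatic carbon, elsewhere in the molecule, gave a 1.0-fold lower number from compound 1 to compound 2 (0.02 log units; within the scatter). A step beyond the scatter in this assay is therefore not expected. The estimated step is a 1.3-fold higher number from compound 3 to compound 4 (0.12 log units; within the scatter). For compound 4 the expected value is 600 nM, within an estimated range of 200 nM to 1800 nM.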

Compound 4, half-maximal inhibitory concentration: 3040 nM
Compound 4: the middle estimate sits 5.1-fold (0.70 log units) below what was measured, outside the stated range (above it).
By their numbers in this assay, from the lowest: compound 3; then compounds 4, 2 and 1 (each within the scatter of the next, the first and the last beyond it).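

The ring on the sulfonyl group matters in this assay: 4-bromophenyl in place of 2,5-dimethylphenyl gives a 6.6-fold higher number from compound 3 to compound 4 (0.82 log units; beyond the scatter). Placing a sulfonyl group on the aromatic nitrogen therefore brings no fixed gain, as (4-bromophenyl)sulfonyl gives only a 2.1-fold lower number from compound 1 to compound 4 (0.31 log units; beyond the scatter). Nothing measured here accounts for this difference.

This swap removes the methyl groups and adds a bromine at once, so the compounds shown cannot separate the two changes. From the compounds shown here alone, how an unsubstituted phenyl ring, or one carrying an amine or a carboxylic acid, would behave on the sulfonyl sulfur remains open.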